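A few compounds are considered here, and "the series" means these few. Any claim that something is new, unique, unknown or untested is made for them only; others in the source may bear on it.

Measured so far:
compound 1, `CC(C)(C)c1ccc(C(=O)N2CCC3(CC2)C(=O)N(CC(=O)NCN)CN3c2ccccc2)cc1`; in an assay on HEK293 cells for displacement of a labelled ligand from NPC1-like intracellular cholesterol transporter 1 (Homo sapiens) (on this read-out lower numbers stand for stronger inhibition and higher numbers for weaker inhibition), compound 1 gives 26500 nM.
compound 2, `CC(C)(C)c1ccc(C(=O)N2CCC3(CC2)C(=O)N(CC(=O)N2CCC(O)CC2)CN3c2ccccc2)cc1`; in this assay compound 2 gives 4700 nM.

Among the compounds with values here, compound 2 holds the lowest of the two numbers; the only measured step is a 5.6-fold lower number from compound 1 to compound 2 (0.75 log units; beyond the scatter).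

Compound 3, `CC(C)(C)c1ccc(C(=O)N2CCC3(CC2)C(=O)N(CC(=O)N2CCCC(C(N)=O)C2)CN3c2ccccc2)cc1`, differs from compound 2 by 3-carbamoylpiperidin-1-yl in place of 4-hydroxypiperidin-1-yl on a carbonyl carbon. The step of a 5.6-fold lower number from compound 1 to compound 2 (0.75 log units; beyond the scatter) concerns a different exchange on a carbonyl carbon and does not test one piperidinyl group against another, so it offers little guidance. The expected step in this assay is a 1.1-fold higher number from compound 2 to compound 3 (0.03 log units; within the scatter), nothing beyond the scatter. Compound 3 is estimated at 5000 nM in this assay, range 1500 nM to 16000 nM.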

Compound 3, half-maximal inhibitory concentration: 16900 nM
Beside the measured number, compound 3's estimate is 3.4-fold (0.53 log units) below it; measured number outside the range, above it.
By their numbers in this assay, from the lowest: compound 2; then compounds 3 and 1 (each within the scatter of the next).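

In this assay, a piperidine ring on this carbonyl carbon does not by itself hold the lower number: 3-carbamoylpiperidin-1-yl in place of 4-hydroxypiperidin-1-yl gives a 3.6-fold higher number from compound 2 to compound 3 (0.56 log units; beyond the scatter) in this series. Against the (aminomethyl)amino group, the same ring gives a 1.6-fold lower number from compound 1 to compound 3 (0.20 log units; within the scatter) and so shows no separation, leaving 4-hydroxypiperidin-1-yl as the only group here that stands apart. No available evidence bears on the reason for this difference.

Still open, as far as these compounds go, is whether the hydroxyl, the carbamoyl group or their placement on the ring decides the result. Plain piperidin-1-yl, 3-hydroxypiperidin-1-yl and 4-carbamoylpiperidin-1-yl on the same carbonyl carbon would separate these possibilities.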